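A Larger Ring on the Carbonyl of Compound 2

The source may report more compounds than this note shows. Statements on the series, on what has been measured and on what is new or still open speak of the compounds shown alone.

In a functional assay on HepG2 cells (Homo sapiens) for inhibition, read by MTT assay, with a stated time of 48 h (a higher number here means a weaker inhibitor, a lower number a stronger inhibitor), compound 1 `COc1ccc(-n2c(SCc3ccc(C)cc3)nnc2-c2cc(OC)c(OC)c(OC)c2)cc1` gives 31600 nM and compound 2 `COc1ccc(-n2c(SCC(=O)c3ccccc3)nnc2-c2cc(OC)c(OC)c(OC)c2)cc1` gives 16200 nM. Among the measured compounds shown here, these are the only two measurements, and they lie within the scatter of each other. Compound 3 `COc1ccc(-n2c(SCC(=O)c3ccc4ccccc4c3)nnc2-c2cc(OC)c(OC)c(OC)c2)cc1` differs from compound 2 by one change, naphthalen-2-yl in place of phenyl on a carbonyl carbon. For the measured compounds named here, the only measured step, a 2.0-fold lower number from compound 1 to compound 2 (0.29 log units; within the scatter), is small and does not test this change, so no shift beyond the scatter is expected. For compound 3, the estimated step is a 1.2-fold lower number from compound 2 to compound 3 (0.06 log units; within the scatter). Compound 3 is expected to give 14000 nM, with an estimated range of 4500 nM to 40000 nM.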

Compound 3, half-maximal inhibitory concentration: > 60000 nM
Compound 3: only a limit was reported; the forecaster's own chance of this, stated with the estimate: 8%; middle value at least 4.2-fold (0.63 log units) from the limit.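

Naphthalen-2-yl in place of phenyl on a carbonyl carbon gives the first change in this series that clears the scatter (an at least 3.7-fold higher number from compound 2 to compound 3 (0.56 log units; beyond the scatter)), so this position does respond to the group it carries. The comparison with compound 1 gives only a floor (an at least 1.8-fold higher number from compound 1 to compound 3 (0.27 log units; that floor lies within the scatter)), and that floor does not clear the scatter. The result for compound 3 is a limit of the assay, not a number: the limit of > 60000 nM in this assay, at which 1 of the 3 values shown sits.

The compounds shown hold only phenyl and naphthalen-2-yl on this carbonyl carbon. On these data alone, how a methyl group, or a phenyl carrying an amine, would fare there remains open.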